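The compounds below may be only part of what the source reports. "The series", "measured", "known", "first", "only" and "open" are said of these compounds alone.

Measured so far in a functional assay on B16-F10 cells (Mus musculus) for antiproliferative activity, read by MTT assay, with a stated time of 48 h; on this read-out higher numbers stand for weaker inhibition and lower numbers for stronger inhibition:
Compound 1 `CC(=O)N1N=C(c2ccc3ccccc3c2)OC1c1ccccc1F` gives 6.05 ug/mL
Compound 2 `CC(=O)N1N=C(c2ccc3ccccc3c2)OC1c1ccc(F)cc1` gives 4.65 ug/mL
Compound 3 `CC(=O)N1N=C(c2ccc3ccccc3c2)OC1c1ccc([N+](=O)[O-])cc1` gives 9.32 ug/mL

Compound 3 does not stand apart from the other two: both of its steps (a 1.5-fold higher number from compound 1 to compound 3 (0.19 log units; within the scatter)) and (a 2.0-fold higher number from compound 2 to compound 3 (0.30 log units; within the scatter)) lie within the scatter. Compound 4 `CC(=O)N1N=C(c2ccc3ccccc3c2)OC1c1ccc(C)cc1` differs from compound 3 by one change, (methyl in place of nitro on an aromatic carbon), in short methyl in place of nitro on an aromatic carbon. Going by the values given here, no measured compound carries this methyl, so the evidence is only indirect. Among the compounds with values here, the one measured exchange of the nitro group (a 2.0-fold higher number from compound 2 to compound 3 (0.30 log units; within the scatter)) stayed within the scatter, as did the remaining step (a 1.3-fold lower number from compound 1 to compound 2 (0.11 log units; within the scatter)). No step beyond the scatter is therefore expected in this assay, at most a slight drift towards lower numbers. The estimated step is small (a 1.6-fold lower number from compound 3 to compound 4 (0.19 log units; within the scatter)) and is expected to stay within the scatter. For compound 4 the estimated value is 6 ug/mL with an expected range from 3 ug/mL to 12 ug/mL.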

Compound 4, half-maximal inhibitory concentration: 3.85 ug/mL
Beside the measured number, compound 4's estimate is 1.6-fold (0.19 log units) above it; low and high end bracket the measured number.
By their numbers in this assay, from the lowest: compounds 4, 2, 1 and 3 (each within the scatter of the next, the first and the last beyond it).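

In this assay, going by these compounds alone, methyl in place of nitro on the aromatic carbon para to a large group gives the only step at this position that passes beyond the scatter, and a modest one (a 2.4-fold lower number from compound 3 to compound 4 (0.38 log units; beyond the scatter)). Methyl does not separate from either fluoro compound (a 1.2-fold lower number from compound 2 to compound 4 (0.08 log units; within the scatter); a 1.6-fold lower number from compound 1 to compound 4 (0.20 log units; within the scatter)), so among these compounds only the nitro and methyl pair can be told apart, and the fluoro compounds cannot be set apart from either end. Nothing measured on these compounds bears on the reason for this step.

The compounds shown leave open whether an amine, a carboxylic acid or a longer chain at this place would move the number beyond the scatter from compound 4. They also leave open how methyl would read at any other place on this ring.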